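Dropping the chloro from the aryl piperazine of compound 1

A few compounds are considered here, and "the series" means these few. Any claim that something is new, unique, unknown or untested is made for them only; others in the source may bear on it.

Within the data shown here, compound 1 `Nc1scc(CN2CCN(c3ccc(Cl)cc3F)CC2)c1C(=O)c1ccc(Cl)cc1` is the stronger of the two numbers so far in a functional assay on CHO cells with adenosine receptor A1 (Homo sapiens) as the target, read by cAMP accumulation and immunoassay, with a stated time of 6 min, tested at 1 uM; a higher number here means a weaker effect of the compound at the concentration tested, a lower number a stronger effect: in this assay compound 1 gives -57%, while compound 2 `Nc1scc(CN2CCN(c3c(F)cccc3F)CC2)c1C(=O)c1cccc(C(F)(F)F)c1` gives 1.3%, a gap beyond the scatter. Compound 2 differs from compound 1 in more than one place, so its two values show only that the two ends of the series lie far apart. Compound 3 `Nc1scc(CN2CCN(c3ccccc3F)CC2)c1C(=O)c1ccc(Cl)cc1` has not yet been run. It differs from compound 1 by hydrogen in place of chloro on an aromatic carbon; cut one bond further out, the change reads 4-chloro-2-fluorophenyl to 2-fluorophenyl. Among the measured compounds shown here, with no single-change step measured, the size of this step is open. The expectation is an upward move, beyond the scatter, from compound 1 to compound 3 of a number 32 percentage points higher from compound 1 to compound 3 (beyond the scatter), because compound 1 sits at -57% and a move back toward compound 2 seems more likely than a further drop. Compound 3 is thus estimated at -25%, with a range from -60% to 15%.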

Compound 3, a percentage reported as activity, at one concentration (the size of the read-out at that concentration, not a potency): -9.2%
Compound 3: the middle estimate sits 15.8 percentage points below what was measured; low and high end bracket the measured number.
By their numbers in this assay, from the lowest: compound 1; then compound 3; then compound 2.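

Hydrogen in place of chloro, on the aromatic carbon meta to a fluoro group and para to a large group, gives a number 47.8 percentage points higher from compound 1 to compound 3 (beyond the scatter) in this assay and so counts as a large step. Among these compounds, this is the first single-change reading: with the rest of compound 1 unchanged, the chloro at this one position accounts for a clear part of its stronger effect. No measurement at hand gives a reason for the step.

Still open, on these data alone, is whether the stronger effect needs chloro itself or also appears with bromo, methyl or methoxy at this position. Also open, as far as these compounds go, is whether the step keeps its size when the 4-chlorophenyl group on the carbonyl is exchanged for another aryl group.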